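Methoxy for Chloro on a Benzyl Group: Expected Response

The source may hold more compounds than are shown below. What is called first, only, known or untested is meant among the compounds shown, and "the series" means these compounds.

Measured so far:
Compound 1, `C=CCn1c(=O)n(CCC(CCOCc2ccccc2)CCOCc2ccccc2)c2nc(N)nc(O)c21`: 68%
Compound 2, `Nc1nc(O)c2c(n1)n(C1OC(CO)[C@@H](O)[C@H]1O)c(=O)n2Cc1ccc(Cl)cc1`: 15%

Both were tested in a functional assay on the whole organism (B cells) with Mus musculus as the target; a lower number here means a smaller maximal response, a higher number a larger maximal response. Compound 2 stands at the lower of the two numbers: compound 1 gives 68%, while compound 2 gives 15%, a gap beyond the usual scatter of this assay.

Compound 3, `COc1ccc(Cn2c(=O)n(C3OC(CO)[C@@H](O)[C@H]3O)c3nc(N)nc(O)c32)cc1`, has not yet been measured. It differs from compound 2 in one place: methoxy in place of chloro on an aromatic carbon. Going by the values given here, no measured pair shows this change, so its effect cannot be read from the numbers at hand. A small step is expected, in either direction or none beyond the scatter.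

Compound 3 is therefore estimated to give 20% in this assay, within a range of 8% to 40%. This estimate means an expected step of a number 5 percentage points higher from compound 2 to compound 3 (within the scatter), which is judged to lie within the scatter.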

Compound 3, largest response reached (reported as maximal response), in percent of the reference or control that the assay uses: 44%
Beside the measured number, compound 3's estimate is 24 percentage points below it, and the stated range ends below it.
By their numbers in this assay, from the lowest: compound 2; then compound 3; then compound 1.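

Methoxy in place of chloro on the benzyl group gives a number 29 percentage points higher from compound 2 to compound 3 (beyond the scatter) in this assay. Going by these compounds alone, this is the first direct reading of this position, since compound 1 differs from compound 2 in more than one place and could not isolate it: the group on this aromatic carbon clearly matters for the maximal response, and even a small replacement moves it. Nothing measured here explains why the response changes with this replacement.

The compounds shown leave open whether the higher response belongs to methoxy alone or would also come with another group at the same place, such as a hydroxyl, an amine or the longer ethoxy. They also leave open whether this replacement would move the response in the same direction on a different core.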